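The source may report more compounds than this note shows. Statements on the series, on what has been measured and on what is new or still open speak of the compounds shown alone.

Compound 1 `CCCCNc1nc(N)nc2c1CN(Cc1ccccc1)CC2` is the reference point. In an assay on HEK293 cells for agonist activity at Toll-like receptor 8 (Homo sapiens), read by a luciferase reporter, with a stated time of 6 h (on this read-out lower numbers stand for an effect already at smaller amounts and higher numbers for an effect only at larger amounts of compound), compound 1 gives 0.06 uM. Compound 2 `CCCCNc1nc(N)nc2c1CN(S(C)(=O)=O)CC2` carries a methylsulfonyl on the ring nitrogen in place of the benzyl, and in this assay compound 2 gives 9.9 uM, so that a 170-fold higher number from compound 1 to compound 2 (2.22 log units; beyond the scatter). Compound 3 `CCCCNc1nc(N)nc2c1CN(C(=O)CC)CC2` has a propanoyl at that same nitrogen, and in this assay compound 3 gives 0.4 uM; it stands second highest of the three numbers, with its smaller step being a 6.7-fold higher number from compound 1 to compound 3 (0.82 log units; beyond the scatter), and furthest from compound 2 since a 25-fold lower number from compound 2 to compound 3 (1.39 log units; beyond the scatter). Compound 4 `CCCCNc1nc(N)nc2c1CN(C(=O)C1CCC1)CC2` is compound 3 altered one step further out: cyclobutyl in place of ethyl on a carbonyl carbon. Cut one bond further out, this reads propanoyl to cyclobutylcarbonyl. All three measured steps alter the group on the ring nitrogen itself; none changes the group on the carbonyl carbon, so none bears directly on this step. For compound 4 a small step is expected, a 1.3-fold lower number from compound 3 to compound 4 (0.12 log units; within the scatter), most likely within the scatter. For compound 4 the estimate in this assay is 0.3 uM, with a range from 0.1 uM to 1 uM.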

Compound 4, minimum effective concentration: 0.4 uM
The estimate for compound 4 lay 1.3-fold (0.12 log units) below the measured number; measured number inside the range.
By their numbers in this assay, from the lowest: compound 1; then compounds 3 and 4 (each within the scatter of the next); then compound 2.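

Putting cyclobutyl in place of ethyl on the carbonyl carbon gives no change at the digits printed from compound 3 to compound 4 (within the scatter), so this first change beyond the ring nitrogen, which adds a four-membered ring of carbon, leaves the read-out where it was. Cyclobutylcarbonyl also stands in the same relation to the other two groups on the ring nitrogen as propanoyl does, with a 25-fold lower number from compound 2 to compound 4 (1.39 log units; beyond the scatter) and a 6.7-fold higher number from compound 1 to compound 4 (0.82 log units; beyond the scatter) as the printed steps. No supporting measurement is available to say why ethyl and cyclobutyl read alike here.

As far as these compounds go, whether a longer chain, a phenyl ring or an amine on the carbonyl carbon would also leave the number unchanged remains open. So does whether any such group could reach the low number of compound 1 0.06 uM with its benzyl.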